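Biphenyl tail and tolerated concentration: compound 3 to compound 4

The compounds below may be only part of what the source reports. "The series", "measured", "known", "first", "only" and "open" are said of these compounds alone.

Measured so far in an ADME assay on A549 cells (Homo sapiens) for cytotoxicity, read by CellTiter-Glo; a lower number here means that less compound is tolerated, a higher number that more compound is tolerated:
compound 1 `Cc1c(Cc2ccc(F)cc2)c(=O)oc2cc(OCC(O)CN3CCC(C(N)=O)CC3)ccc12` gives 89300 nM
compound 2 `Cc1c(Cc2ccc(Br)cc2)c(=O)oc2cc(OCC(O)CN3CCC(C(N)=O)CC3)ccc12` gives > 100000 nM, a limit of the assay
compound 3 `Cc1c(Cc2ccc(-c3ccc(F)cc3)cc2)c(=O)oc2cc(OCC(O)CN3CCC(C(N)=O)CC3)ccc12` gives 19300 nM

Compound 3 stands lowest of the two numbers shown; compound 1 is its nearest neighbour, and the step of a 4.6-fold lower number from compound 1 to compound 3 (0.67 log units; beyond the scatter) is beyond the scatter. Compound 2 sits at a limit (the limit of > 100000 nM in this assay, at which 1 of the 3 values shown sits), so its gap to compound 3 is only known as a floor, an at least 5.1-fold lower number from compound 2 to compound 3 (0.71 log units; beyond the scatter).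

Compound 4 `Cc1c(Cc2ccc(-c3ccc(C(F)(F)F)cc3)cc2)c(=O)oc2cc(OCC(O)CN3CCC(C(N)=O)CC3)ccc12` carries the change (trifluoromethyl in place of fluoro on an aromatic carbon). Among the measured compounds shown here, the steps that bear on this position are a 4.6-fold lower number from compound 1 to compound 3 (0.67 log units; beyond the scatter) and an at least 5.1-fold lower number from compound 2 to compound 3 (0.71 log units; beyond the scatter), both modest and both toward a lower number, whereas the halogen swap an at least 1.1-fold higher number from compound 1 to compound 2 (0.04 log units; that floor lies within the scatter) lay within the scatter. Compound 4 keeps the biphenyl of compound 3 and only alters its far end, so the expected step of a 1.6-fold lower number from compound 3 to compound 4 (0.21 log units; within the scatter) is small, toward a somewhat lower number at most, and may lie within the scatter. Compound 4 is thus estimated at 12000 nM, between 5000 nM and 35000 nM.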

Compound 4, half-maximal cytotoxic concentration: > 100000 nM
Compound 4: only a limit was reported; the forecaster's own chance of this, stated with the estimate: 5%; at least 8.3-fold (0.92 log units) between middle value and limit.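

In this assay the biphenyl tail alone does not set the number, since the group at its end decides the outcome: trifluoromethyl in place of fluoro gives a clear rise (an at least 5.1-fold higher number from compound 3 to compound 4 (0.71 log units; beyond the scatter)). Against compound 1, the 4-(trifluoromethyl)phenyl tail gives only a floor that lies within the scatter (an at least 1.1-fold higher number from compound 1 to compound 4 (0.04 log units; that floor lies within the scatter)), and the step between compound 2 and compound 4 cannot be read. So far the lower number belongs to compound 3 alone among the biphenyls, and the result for compound 4 is a limit of the assay, as is that for compound 2: the limit of > 100000 nM in this assay, at which 2 of the 4 values shown sit.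

As far as these compounds go, how far compound 4 lies beyond that limit stays open, so its true distance from compound 1 and compound 2 is unknown. Also open, from the compounds shown here alone, is whether an amine, a carboxylic acid or a nitrile in place of the trifluoromethyl would stay near compound 3 or move to the limit.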